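The source may hold more compounds than are shown below. What is called first, only, known or untested is meant among the compounds shown, and "the series" means these compounds.

Compound 1 `COc1ccc(-n2cc(-c3ccccc3)c(-c3ccc4c(c3)NC(=O)CO4)n2)cc1` gives 59.9% in a functional assay on MV4-11 cells (Homo sapiens) for cytotoxicity, read by colorimetric assay and MTT assay, with a stated time of 3 days, tested at 20 uM; a higher number here means a weaker effect of the compound at the concentration tested, a lower number a stronger effect. Compound 2 `Cc1ccccc1-n1cc(-c2ccccc2)c(-c2ccc3c(c2)NC(=O)CO3)n1` gives 54.2% in this assay. Compound 3 `O=C1COc2ccc(-c3nn(-c4ccc(Cl)cc4)cc3-c3ccccc3)cc2N1` gives 91.9% in this assay.

On these numbers compound 3 stands highest, the weakest effect of the three: a number 32 percentage points higher from compound 1 to compound 3 (beyond the scatter) and a number 37.7 percentage points higher from compound 2 to compound 3 (beyond the scatter). Compound 4 `O=C1COc2ccc(-c3nn(-c4ccc(F)cc4)cc3-c3ccccc3)cc2N1` has not yet been measured; it differs from compound 3 in one place only: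

fluoro in place of chloro on an aromatic carbon

Within the data shown here, no measured step exchanges one halogen for another, so only the two large steps into compound 3 bear on the question. Because a number 32 percentage points higher from compound 1 to compound 3 (beyond the scatter) shows that the group at this place moves the read-out strongly, compound 4 is expected to land between those extremes, with a moderate step of a number 13.9 percentage points lower from compound 3 to compound 4 (beyond the scatter) expected. Compound 4 is therefore estimated at 78% in this assay, within 55% to 100%.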

Compound 4, a percentage reported as activity, at one concentration (the size of the read-out at that concentration, not a potency): 92.6%
Compound 4: the middle estimate sits 14.6 percentage points below what was measured, and the stated range covers the measured number.
By their numbers in this assay, from the lowest: compounds 2 and 1 (each within the scatter of the next); then compounds 3 and 4 (each within the scatter of the next).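

In this assay, exchanging one halogen for the other at this place, para to a large group, makes no readable difference (a number 0.7 percentage points higher from compound 3 to compound 4 (within the scatter)). The large gaps to the methoxy and 2-methylphenyl compounds also persist with fluoro (a number 32.7 percentage points higher from compound 1 to compound 4 (beyond the scatter); a number 38.4 percentage points higher from compound 2 to compound 4 (beyond the scatter)). The high read-out of compound 3 is therefore not unique to chloro, but is shared by the 4-fluorophenyl group.

Going by these compounds, whether an amine or a carboxylic acid at this place would give a similarly high read-out stays open. Nothing available explains why the two halogens read alike.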